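The source may hold more compounds than are shown below. What is called first, only, known or untested is meant among the compounds shown, and "the series" means these compounds.

Among the compounds with values here, compound 1 `COc1ccccc1-c1cc(-c2ccc(Br)cc2)[nH]c(=N)c1C#N` is the only compound of this set with a number in a functional assay on HT-29 cells (Homo sapiens) for inhibition, read by luminescence, with a stated time of 72 h; a lower number here means a stronger inhibitor, a higher number a weaker inhibitor: compound 1 gives 50000 nM, a weak result. Compound 2 `CCOc1ccccc1-c1cc(-c2ccc(Br)cc2)[nH]c(=O)c1C#N` has "not determined" (no result reported) in this assay, so it offers nothing to compare against. Compound 3 `N#Cc1c(-c2cccs2)cc(-c2ccc(Br)cc2)[nH]c1=N` differs from compound 1 by thiophen-2-yl in place of 2-methoxyphenyl on an aromatic carbon. Within the data shown here, no step between measured compounds exists to guide the reading of this change, so the shift is expected to stay within the usual scatter, in neither direction, giving a 1.1-fold lower number from compound 1 to compound 3 (0.05 log units; within the scatter) as the expected step. Compound 3 is therefore estimated at 45000 nM, within a range from 8000 nM to 100000 nM.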

Compound 3, half-maximal inhibitory concentration: 35000 nM
For compound 3 the middle estimate is 1.3-fold (0.11 log units) above the measured one; low and high end bracket the measured number.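

In this assay, the position opposite the ring nitrogen now has its first reading: thiophen-2-yl in place of 2-methoxyphenyl gives a 1.4-fold lower number from compound 1 to compound 3 (0.15 log units; within the scatter). This position therefore accepts a five-membered sulfur-containing ring in place of the larger six-membered carbon ring with no measurable difference in the number. Nothing measured here offers an explanation for this result. From the compounds shown here alone, whether an amine, a carboxylic acid or a cyclohexyl group at this position would separate from compound 1 remains open. So does the effect of replacing the 4-bromophenyl group with a pyridyl ring.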